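The source may hold more compounds than are shown below. What is called first, only, known or untested is meant among the compounds shown, and "the series" means these compounds.

Compound 3 `CCCCc1cnc(CCc2ccc(-c3ccccc3C(=O)O)cc2)[nH]1` gives 2710 nM in an in vitro functional assay on cells for agonist activity at Bombesin receptor subtype-3 (Homo sapiens), read by luminescence and calcium flux; on this read-out lower numbers stand for an effect already at smaller amounts and higher numbers for an effect only at larger amounts of compound; none of the other two numbers falls below it, yet both sit within the scatter of it. Compound 1 `CCCCc1cnc(C(C)Cc2ccc(-c3ccccc3C(=O)O)cc2)[nH]1` gives 2760 nM, and compound 2 `CCCCc1cnc(C(Cc2ccc(-c3ccccc3C(=O)O)cc2)C(C)C)[nH]1` gives 4620 nM. The step of a 1.0-fold lower number from compound 1 to compound 3 (0.01 log units; within the scatter) and the step of a 1.7-fold lower number from compound 2 to compound 3 (0.23 log units; within the scatter) are both small. Compound 4 `CCCCc1cnc(C(CCCO)Cc2ccc(-c3ccccc3C(=O)O)cc2)[nH]1` arises through the change (3-hydroxypropyl in place of hydrogen on a saturated chain carbon bound to an aromatic carbon and a saturated chain carbon). The two earlier changes at this same carbon, small methyl and bulkier isopropyl, left the read-out essentially unchanged, which suggests that a substituent here matters little; a hydroxypropyl has not been tried, so some added uncertainty remains. Compound 4 is therefore expected to give 3000 nM, between 1000 nM and 9000 nM, a step of a 1.1-fold higher number from compound 3 to compound 4 (0.04 log units; within the scatter) expected to stay within the scatter.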

Compound 4, half-maximal effective concentration: 1900 nM
For compound 4 the middle estimate is 1.6-fold (0.20 log units) above the measured one; measured number inside the range.
By their numbers in this assay, from the lowest: compounds 4, 3, 1 and 2 (each within the scatter of the next, the first and the last beyond it).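

In this assay, among these compounds, the group on this saturated chain carbon turns out not to be wholly indifferent: 3-hydroxypropyl in place of isopropyl gives the only step here beyond the scatter (a 2.4-fold lower number from compound 2 to compound 4 (0.39 log units; beyond the scatter)). Set against the compounds carrying hydrogen and methyl, the hydroxyl-bearing chain stays within the scatter (a 1.4-fold lower number from compound 3 to compound 4 (0.15 log units; within the scatter)) and (a 1.5-fold lower number from compound 1 to compound 4 (0.16 log units; within the scatter)). This carbon therefore accepts a chain ending in a hydroxyl while the number stays level with that of compound 3. On these data alone, whether an amine, a carboxylic acid or a longer chain here would shift the number further remains open. Nothing measured here explains the gap between isopropyl and 3-hydroxypropyl.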